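Removing a Methyl From the Ring Oxygen: Expected Cytotoxicity

The compounds below may be only part of what the source reports. "The series", "measured", "known", "first", "only" and "open" are said of these compounds alone.

Compound 1 `COc1cc(/C=N/NC(=O)c2ccncc2)cc(OC)c1O` was tested in a functional assay on cells (Mus musculus) for cytotoxicity, read by MTT assay, with a stated time of 24 h, tested at 1 uM (on this read-out lower numbers stand for a weaker effect and higher numbers for a stronger effect at the one concentration tested), where compound 1 gives 34%, the second highest of the three numbers measured. Compound 2 `COc1cc(/C=N/NC(=O)OCc2ccccc2)cc(OC)c1O` gives 45%, and compound 3 `COc1cc(/C=N/NC(=O)c2ccncc2)cc(OC)c1OC` gives 4%. The change to the carbonyl side gave a number 11 percentage points higher from compound 1 to compound 2 (beyond the scatter); adding a methyl on a ring oxygen gave a number 30 percentage points lower from compound 1 to compound 3 (beyond the scatter). Compound 4 `COc1cc(/C=N/NC(=O)c2ccncc2)cc(O)c1O` differs from compound 1 by hydrogen in place of methyl on an oxygen on an aromatic ring. The step from compound 1 to compound 2 alters another part and does not bear on this. The step from compound 1 to compound 3 is the same kind of change run backwards, though on another oxygen, so a modest rise of a number 11 percentage points higher from compound 1 to compound 4 (beyond the scatter) is expected. Compound 4 is estimated at 45%, between 25% and 65%.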

Compound 4, a percentage reported as activity, at one concentration (the size of the read-out at that concentration, not a potency): 41%
Beside the measured number, compound 4's estimate is 4 percentage points above it; the range from low to high includes it.
By their numbers in this assay, from the lowest: compound 3; then compounds 1, 4 and 2 (each within the scatter of the next, the first and the last beyond it).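

Within this assay hydroxy in place of methoxy on this ring oxygen gives a number 7 percentage points higher from compound 1 to compound 4 (within the scatter) and so leaves no change that stands clear of the usual scatter. Adding a methyl on the hydroxy oxygen of compound 1 instead gives a number 30 percentage points lower from compound 1 to compound 3 (beyond the scatter) and shows that these ring oxygens do not respond alike to a methyl change. Nothing available explains that difference.

From the compounds shown here alone, whether this position would also tolerate a longer chain such as propoxy, or an amine in place of the oxygen, remains open. Also open, going by these compounds, is how hydroxy here would behave with the benzyloxy carbonyl side of compound 2.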